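Nitro to Chloro Swap in a Small Cytotoxicity Series

A few compounds are considered here, and "the series" means these few. Any claim that something is new, unique, unknown or untested is made for them only; others in the source may bear on it.

The study compares three measured compounds and one awaiting measurement in an ADME assay on RAW264.7 cells (Mus musculus) for cytotoxicity, read by MTT assay, with a stated time of 72 h, tested at 50 uM; on this read-out higher numbers stand for a stronger effect at the one concentration tested and lower numbers for a weaker effect. Compound 1 `O=C(Cn1c(=O)oc2cc(Cl)ccc21)Nc1ccccc1` gives 15.8% in this assay, compound 2 `O=C(Cn1c(=O)oc2cc([N+](=O)[O-])ccc21)Nc1ccccc1` gives 18%, and compound 3 `O=C(Cn1c(=O)oc2cc([N+](=O)[O-])ccc21)NCc1ccccn1` gives 21.8%. All three numbers lie within the scatter of one another, so none can be singled out as stronger or weaker.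

Two single changes link them. From compound 2 to compound 1 the change is chloro in place of nitro on an aromatic carbon, and the step is a number 2.2 percentage points lower from compound 2 to compound 1 (within the scatter). From compound 2 to compound 3 the change is (pyridin-2-yl)methyl in place of phenyl on an amide-type nitrogen, with a step of a number 3.8 percentage points higher from compound 2 to compound 3 (within the scatter); this is also how the core of compound 3 differs from the core of compound 2.

Compound 4 `O=C(Cn1c(=O)oc2cc(Cl)ccc21)NCc1ccccn1` has not yet been measured in this assay. It arises from compound 3 by chloro in place of nitro on an aromatic carbon, the same change that leads from compound 2 to compound 1, since the place is described in identical words in both cases. Because that earlier change produced only a number 2.2 percentage points lower from compound 2 to compound 1 (within the scatter), compound 4 is expected to sit close to compound 3, with an estimated step of a number 2.2 percentage points lower from compound 3 to compound 4 (within the scatter). On this basis compound 4 is estimated at 19.6%, with a likely range from 10% to 30%.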

Compound 4, a percentage reported as inhibition, at one concentration (the size of the read-out at that concentration, not a potency): 36.2%
For compound 4 the middle estimate is 16.6 percentage points below the measured one; measured number outside the range, above it.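

In this assay, chloro in place of nitro on an aromatic carbon did not carry over from one core to the other, giving a number 14.4 percentage points higher from compound 3 to compound 4 (beyond the scatter), and the two readings of this change differ: the same change on two cores in this assay, a number 2.2 percentage points lower (within the scatter) from compound 2 to compound 1 and a number 14.4 percentage points higher (beyond the scatter) from compound 3 to compound 4, 16.6 percentage points apart, beyond the scatter of two such steps

The other change behaves in the same way, with (pyridin-2-yl)methyl in place of phenyl on an amide-type nitrogen giving a number 20.4 percentage points higher from compound 1 to compound 4 (beyond the scatter) on the core of compound 1, which does not match its step on the core of compound 2: the same change on two cores in this assay, a number 3.8 percentage points higher (within the scatter) from compound 2 to compound 3 and a number 20.4 percentage points higher (beyond the scatter) from compound 1 to compound 4, 16.6 percentage points apart, beyond the scatter of two such steps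

Both comparisons rest on the same four compounds, so they are one finding seen from two sides: in this series, the size of each change depends on the group present at the other place, but the numbers do not show why, and a single compound carries the whole difference.

The compounds shown leave open whether the higher reading of compound 4 would recur with another group in place of nitro, such as a methoxy group or an amine, or with a benzyl group or a longer chain on the amide nitrogen. From the compounds shown here alone, it also remains open whether the same difference would appear at concentrations other than the one tested.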